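Chain extension at the ring nitrogen of compound 3

This account rests on a few compounds, and the source may have more. Where it says the series, first, only, none or still open, it means among the compounds named here.

Compound 1 `CC(C)CCn1cnc2c(Nc3ccc(Cl)cc3)nc(N[C@H]3CC[C@H](N)CC3)nc21` and compound 2 `CCCCn1cnc2c(Nc3ccc(Cl)cc3)nc(N[C@H]3CC[C@H](N)CC3)nc21` carry the same core; in a functional assay on BT-474 cells (Homo sapiens) for inhibition, read by fluorescence, with a stated time of 72 h (on this read-out higher numbers stand for weaker inhibition of growth and lower numbers for stronger inhibition of growth), compound 1 gives 5100 nM and compound 2 gives 7300 nM, the step of a 1.4-fold higher number from compound 1 to compound 2 (0.16 log units; within the scatter). Compound 3 `CCCCn1cnc2c(Nc3cccc(Cl)c3)nc(N[C@H]3CC[C@H](N)CC3)nc21` gives 5100 nM, the step of a 1.4-fold lower number from compound 2 to compound 3 (0.16 log units; within the scatter); it sits at the same digits as compound 1, with compound 2 within the scatter of both. Compound 4 `CC(C)=CCC/C(C)=C/Cn1cnc2c(Nc3cccc(Cl)c3)nc(N[C@H]3CC[C@H](N)CC3)nc21` differs from compound 3 by 2,6-dimethylhepta-1,5-dien-1-yl in place of propyl on a saturated chain carbon bound to an aromatic nitrogen. Within the data shown here, only the chain step a 1.4-fold higher number from compound 1 to compound 2 (0.16 log units; within the scatter) bears on this, and it was small; the entering chain is far larger than that step covered, so no measured step sets its size. A step of a 1.3-fold higher number from compound 3 to compound 4 (0.11 log units; within the scatter) is expected, wider than the scatter only in uncertainty. Compound 4 is estimated at 6500 nM, within 2000 nM to 20000 nM.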

Compound 4, concentration for 50% growth inhibition: 4300 nM
The estimate for compound 4 lay 1.5-fold (0.18 log units) above the measured number; measured number inside the range.
By their numbers in this assay, from the lowest: compounds 4, 1, 3 and 2 (each within the scatter of the next).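

In this assay, 2,6-dimethylhepta-1,5-dien-1-yl in place of propyl on a saturated chain carbon bound to an aromatic nitrogen gives a 1.2-fold lower number from compound 3 to compound 4 (0.07 log units; within the scatter). This position therefore accepts a far larger unsaturated hydrocarbon chain than the earlier chain step covered, with the read-out staying within the scatter. No available evidence accounts for this flat response.

Every chain shown here is a pure hydrocarbon. From the compounds shown here alone, whether a chain ending in an amine or a carboxylic acid would move the number beyond the scatter remains open.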